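A few compounds are considered here, and "the series" means these few. Any claim that something is new, unique, unknown or untested is made for them only; others in the source may bear on it.

Measured compounds:
compound 1 `CC(C)CNc1ccc(NC(=O)c2cc(Cl)ccc2O)c(Cl)c1` with 60000 nM
compound 2 `O=C(Nc1ccc(NCc2cc(F)cc(Cl)c2)cc1Cl)c1cc(Cl)ccc1O` with 11100 nM

Compound 1 `CC(C)CNc1ccc(NC(=O)c2cc(Cl)ccc2O)c(Cl)c1` holds the highest number of the two measured in an ADME assay on A549 cells (Homo sapiens) for cytotoxicity, read by resazurin assay, with a stated time of 48 h (on this read-out higher numbers stand for lower toxicity in this test and lower numbers for higher toxicity in this test), where compound 1 gives 60000 nM. Its nearest neighbour is compound 2 `O=C(Nc1ccc(NCc2cc(F)cc(Cl)c2)cc1Cl)c1cc(Cl)ccc1O`, which in this assay gives 11100 nM; the step of a 5.4-fold lower number from compound 1 to compound 2 (0.73 log units; beyond the scatter) is beyond the scatter.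

Compound 3 `O=C(Nc1ccc(NCc2ccncc2)cc1Cl)c1cc(Cl)ccc1O` has not yet been measured. It differs from compound 1 in one place: pyridin-4-yl in place of isopropyl on a saturated chain carbon bound to a nitrogen on an aromatic ring. Among the compounds with values here, the only measured step that bears on this change is the one in which 3-chloro-5-fluorophenyl replaced isopropyl at the same place, a 5.4-fold lower number from compound 1 to compound 2 (0.73 log units; beyond the scatter). That step put an aromatic ring on the saturated chain carbon bound to the nitrogen on the aromatic ring, as the change to compound 3 also does, though the entering ring here carries one nitrogen and no halogen. Within the data shown here, on this basis a step in the same direction, somewhat smaller than the one to compound 2, is expected for compound 3 in this assay, namely a 2.4-fold lower number from compound 1 to compound 3 (0.38 log units; beyond the scatter). Compound 3 is therefore estimated at 25000 nM, with a range from 8000 nM to 70000 nM.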

Compound 3, half-maximal cytotoxic concentration: 65300 nM
For compound 3 the middle estimate is 2.6-fold (0.42 log units) below the measured one, within the range that was stated.
By their numbers in this assay, from the lowest: compound 2; then compounds 1 and 3 (each within the scatter of the next).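

In this assay, pyridin-4-yl in place of isopropyl on a saturated chain carbon bound to a nitrogen on an aromatic ring leaves the number within the scatter (a 1.1-fold higher number from compound 1 to compound 3 (0.04 log units; within the scatter)), so an aromatic ring at this place does not by itself go with a lower number. Exchanging the one ring for the other at the same place does move the number beyond the scatter (a 5.9-fold higher number from compound 2 to compound 3 (0.77 log units; beyond the scatter)), which ties the lower number of compound 2 to the 3-chloro-5-fluorophenyl group in particular, not to the presence of any ring on that chain carbon. Nothing available on these compounds offers an explanation for this difference between the two rings.

The two entering rings differ at once in the ring nitrogen and in the chlorine and fluorine they carry, so the compounds shown cannot say which of these features goes with the change; an unsubstituted phenyl or a 3-chlorophenyl group at this place would begin to separate them. Going by these compounds, how a pyridin-3-yl ring, a saturated ring such as cyclohexyl, or a chain ending in an amine or a carboxylic acid would read here also remains open.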